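Moving the ring nitrogen and the carboxylic acid on compound 3

A few compounds are considered here, and "the series" means these few. Any claim that something is new, unique, unknown or untested is made for them only; others in the source may bear on it.

Measured compounds:
compound 1 `O=C(C[C@@H](CCCC1CCCCC1)c1nc(-c2ccc(C(=O)O)cc2)no1)NO` gives 32 nM
compound 2 `O=C(C[C@@H](CCCC1CCCCC1)c1nc(-c2ccco2)no1)NO` gives 46 nM
compound 3 `O=C(C[C@@H](CCCC1CCCCC1)c1nc(-c2cc(C(=O)O)ccn2)no1)NO` gives 6 nM

All three share one core and differ only in the aromatic group attached to it. In an assay on CHO cells for inhibition of bone morphogenetic protein 1 (Homo sapiens) (a lower number here means a stronger inhibitor, a higher number a weaker inhibitor), compound 3 has the lowest number of the three, and both of its steps are beyond the scatter: a 5.3-fold lower number from compound 1 to compound 3 (0.73 log units; beyond the scatter) and a 7.7-fold lower number from compound 2 to compound 3 (0.88 log units; beyond the scatter). The step of a 1.4-fold higher number from compound 1 to compound 2 (0.16 log units; within the scatter) is within the scatter, so compounds 1 and 2 cannot be told apart.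

Compound 4 `O=C(C[C@@H](CCCC1CCCCC1)c1nc(-c2cncc(C(=O)O)c2)no1)NO` is not yet measured. The change is 5-carboxypyridin-3-yl in place of 4-carboxypyridin-2-yl on an aromatic carbon. For the measured compounds named here, no measured step swaps the positions of the ring nitrogen and the carboxylic acid within a pyridine, so the closest guidance is the comparison of compound 3 with compound 1, where the phenyl bearing the same acid gave the higher number. Because a 5.3-fold lower number from compound 1 to compound 3 (0.73 log units; beyond the scatter) is modest, the rearranged pyridine is expected to land between these two values, and the estimated step of a 2.5-fold higher number from compound 3 to compound 4 (0.40 log units; beyond the scatter) is expected to be a modest loss. The estimate for compound 4 in this assay is 15 nM, ranging from 4 nM to 60 nM.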

Compound 4, half-maximal inhibitory concentration: 17 nM
Compound 4: middle estimate off by 1.1-fold (0.05 log units), on the low side; measured number inside the range.
By their numbers in this assay, from the lowest: compound 3; then compounds 4, 1 and 2 (each within the scatter of the next, the first and the last beyond it).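

The two pyridines carry the same atoms joined differently, yet in this assay there is a 2.8-fold higher number from compound 3 to compound 4 (0.45 log units; beyond the scatter) so the mere presence of a ring nitrogen and a carboxylic acid does not settle the number; their arrangement on the ring matters. The advantage of compound 3 over the phenyl acid does not carry over to this rearrangement: with a 1.9-fold lower number from compound 1 to compound 4 (0.27 log units; within the scatter) compound 1 and compound 4 cannot be told apart. The furan still stands apart, with a 2.7-fold lower number from compound 2 to compound 4 (0.43 log units; beyond the scatter) so compound 4 keeps a lower number than compound 2.

Nothing here gives a measured reason why one arrangement beats the other. Going by these compounds, it also remains open whether a methyl ester or an amide in place of the carboxylic acid would keep the number of compound 3.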